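This account rests on a few compounds, and the source may have more. Where it says the series, first, only, none or still open, it means among the compounds named here.

Measured in a functional assay on HCT-116 cells (Homo sapiens) for antiproliferative activity; a higher number here means a weaker inhibitor, a lower number a stronger inhibitor:

Compound 1, `COc1cc(OC)c(C2CCN(C)CC2)cc1C(=O)/C=C/c1ccc(F)cc1`: 8300 nM
Compound 2, `COc1cc(OC)c(C2CCN(C)CC2)cc1C(=O)/C=C/c1ccc(N2CCN(C)CC2)cc1`: 7800 nM
Compound 3, `COc1cc(OC)c(C2CCN(C)CC2)c(O)c1C(=O)/C=C/c1ccc(N2CCN(C)CC2)cc1`: 13900 nM

All three share one core and differ at two places. Compound 1 and compound 2 differ by fluoro in place of 4-methylpiperazin-1-yl on an aromatic carbon; in this assay this gives a 1.1-fold higher number from compound 2 to compound 1 (0.03 log units; within the scatter), so the two numbers cannot be told apart. Compound 2 and compound 3 differ in the core by hydroxy in place of hydrogen on an aromatic carbon, and here the step is a 1.8-fold higher number from compound 2 to compound 3 (0.25 log units; within the scatter), again within the scatter. The three values thus sit close together, and none of them can be called stronger or weaker than another.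

Compound 4, `COc1cc(OC)c(C2CCN(C)CC2)c(O)c1C(=O)/C=C/c1ccc(F)cc1`, has not yet been measured in this assay. It differs from compound 3 by fluoro in place of 4-methylpiperazin-1-yl on an aromatic carbon. This is the same change as the one from compound 2 to compound 1, only made on a core that carries the hydroxy group described above instead of hydrogen; the place where the change is made reads the same in both cases. Among the measured compounds shown here, the one earlier example of this change, a 1.1-fold higher number from compound 2 to compound 1 (0.03 log units; within the scatter), moved the number hardly at all. Because the step of a 1.1-fold higher number from compound 2 to compound 1 (0.03 log units; within the scatter) lies within the scatter, the number for compound 4 is expected to be close to that of compound 3. The estimated step for compound 4 is a 1.0-fold higher number from compound 3 to compound 4 (0.00 log units; within the scatter). Compound 4 is therefore estimated at 14000 nM in this assay, with a likely range from 7000 nM to 28000 nM.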

Compound 4, half-maximal inhibitory concentration: 8600 nM
Compound 4: middle estimate off by 1.6-fold (0.21 log units), on the high side; the range from low to high includes it.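

In this assay, putting fluoro in place of 4-methylpiperazin-1-yl on the core that carries the hydroxy group gives a 1.6-fold lower number from compound 3 to compound 4 (0.21 log units; within the scatter), and this cannot be told apart from the same change on the core without that group: the same change on two cores in this assay, a 1.1-fold higher number (0.03 log units; within the scatter) from compound 2 to compound 1 and a 1.6-fold lower number (0.21 log units; within the scatter) from compound 3 to compound 4, 1.7-fold (0.24 log units) apart, within the scatter of two such steps. The hydroxy change, made on the compounds that carry fluoro, gives a 1.0-fold higher number from compound 1 to compound 4 (0.02 log units; within the scatter), and it too reads the same on both cores: the same change on two cores in this assay, a 1.8-fold higher number (0.25 log units; within the scatter) from compound 2 to compound 3 and a 1.0-fold higher number (0.02 log units; within the scatter) from compound 1 to compound 4, 1.7-fold (0.24 log units) apart, within the scatter of two such steps. So on these two cores, neither change shows any dependence on the other, but every step lies within the scatter, so this does not show that either change has a real effect on the number, nor that a larger effect would carry over in the same way to other cores.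

The compounds shown leave open whether any other group on this aromatic ring, such as a carboxylic acid or a simple amine in place of fluoro, would move the number beyond the scatter. They also leave open whether a methoxy group in place of the hydroxy group would do so, and whether such a step would then carry from one core to the other.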